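Swapping Trifluoromethyl for Methyl in a Stability Series

The compounds below may be only part of what the source reports. "The series", "measured", "known", "first", "only" and "open" are said of these compounds alone.

Measured so far in an ADME assay on microsomes from liver (Mus musculus) for metabolic stability, read by LC-MS, with a stated time of 30 min, tested at 1 uM; on this read-out lower numbers stand for a less stable compound and higher numbers for a more stable compound

Compound 1 `O=C(NCc1ccc(S(=O)(=O)c2cccc(C(F)(F)F)c2)cc1)c1cc2cnccc2[nH]1` gives 49%
Compound 2 `O=C(NCc1ccc(S(=O)(=O)c2cccc(C(F)(F)F)c2)cc1)c1cc2ccncc2s1` gives 35%

Compound 1 stands highest of these two numbers, and compound 2 lies lower by more than the usual scatter. Compound 3 `Cc1cccc(S(=O)(=O)c2ccc(CNC(=O)c3cc4cnccc4[nH]3)cc2)c1` has not yet been measured in this assay and differs from compound 1 in one place methyl in place of trifluoromethyl on an aromatic carbon with methyl in place of trifluoromethyl on an aromatic carbon. Within the data shown here, the only measured step is a number 14 percentage points lower from compound 1 to compound 2 (beyond the scatter) and it changes the group on a carbonyl carbon, not this one. Among the measured compounds shown here, it therefore offers only a rough guide to size, and no measurement yet tests the new change. Starting from the higher of two values, a modest fall is expected. The expected step is a number 12 percentage points lower from compound 1 to compound 3 (beyond the scatter) and it remains uncertain. The estimate for compound 3 is 37% with an expected range from 17% to 57% in this measurement.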

Compound 3, percent of the compound remaining: 32%
Beside the measured number, compound 3's estimate is 5 percentage points above it; measured number inside the range.
By their numbers in this assay, from the lowest: compounds 3 and 2 (each within the scatter of the next); then compound 1.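

Going from trifluoromethyl to methyl on this aromatic carbon gives in this assay a number 17 percentage points lower from compound 1 to compound 3 (beyond the scatter) and is the first reading at this end of the molecule. The earlier pair differed only in the group on the carbonyl carbon, so this step adds that the number also responds to a change on the 3-(trifluoromethyl)phenyl part, with trifluoromethyl carrying the higher value of this pair. No measured evidence at hand explains the size or direction of this step.

Among these compounds, with only two groups compared on this carbon, it remains open whether the value follows a graded trend or is particular to trifluoromethyl. A chlorine atom, a methoxy group or a nitrile in the same place could help settle that, and the same swap on the core of compound 2 would test whether the step carries over.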